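Boc removal on the biphenylmethyl diamine series

The source may report more compounds than this note shows. Statements on the series, on what has been measured and on what is new or still open speak of the compounds shown alone.

Four compounds on a shared linear polyamine core are considered here. Compound 1 has the structure `CC(C)(C)OC(=O)NCCCCNCCCN(Cc1ccc(F)cc1)Cc1ccc(F)cc1` and compound 3 the structure `NCCCCNCCCN(Cc1ccc(F)cc1)Cc1ccc(F)cc1`; their biphenyl counterparts are compound 2, `CC(C)(C)OC(=O)NCCCCNCCCN(Cc1cccc(-c2ccccc2)c1)Cc1cccc(-c2ccccc2)c1`, and compound 4, `NCCCCNCCCN(Cc1cccc(-c2ccccc2)c1)Cc1cccc(-c2ccccc2)c1`, the last not yet measured. The difference between the core of compound 1 and the core of compound 2 is not broken down here.

In an ADME assay on RAW264.7 cells (Mus musculus) for cytotoxicity, read by resazurin assay, with a stated time of 48 h (on this read-out higher numbers stand for lower toxicity in this test and lower numbers for higher toxicity in this test), compound 1 gives 8700 nM. Compound 3 differs from compound 1 by hydrogen in place of tert-butoxycarbonyl on an amine nitrogen. In this assay compound 3 gives 33100 nM. That change produced a 3.8-fold higher number from compound 1 to compound 3 (0.58 log units; beyond the scatter). Compound 2 in this assay gives only a limit, > 100000 nM, not a number. That limit is the limit of > 100000 nM in this assay, at which 1 of the 3 values shown sits.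

Among the measured compounds shown here, compound 4 differs from compound 2 by hydrogen in place of tert-butoxycarbonyl on an amine nitrogen, which is the same change as the one from compound 1 to compound 3, made at the same place on the same kind of amine nitrogen. On the measured pair the change moved the number upward, so for compound 4 the expected step is a step that the limit leaves unreadable from compound 2 to compound 4, resting on compound 3 giving 33100 nM against compound 1 at 8700 nM. Since compound 2 already sits at the limit, compound 4 is expected to reach or exceed it, with an estimated value of 200000 nM and a likely range from 60000 nM to 700000 nM; most probably this assay will again report only a limit for compound 4.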

Compound 4, half-maximal cytotoxic concentration: 30300 nM
Compound 4: the middle estimate sits 6.6-fold (0.82 log units) above what was measured; the measured number lies below the stated range.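

In this assay, hydrogen in place of tert-butoxycarbonyl on an amine nitrogen gives an at least 3.3-fold lower number from compound 2 to compound 4 (0.51 log units; beyond the scatter), so the direction seen on the core of compound 1 does not carry over to the core of compound 2: the same change on two cores in this assay, a 3.8-fold higher number (0.58 log units; beyond the scatter) from compound 1 to compound 3 and an at least 3.3-fold lower number (0.51 log units; beyond the scatter) from compound 2 to compound 4, at least 12-fold (1.09 log units) apart, beyond the scatter of two such steps

Compound 2 gives > 100000 nM, which is a limit of the assay and not a number, so the step has a floor but no measured size.

The two pairs show that, in these compounds, the outcome of this change is not transferable from one core to the other, but they give no reason for the reversal and no rule for any further core.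

Still open, going by these compounds, is which part of the difference between the core of compound 1 and the core of compound 2 sets the direction of the step, and whether an unsubstituted benzyl group in their place would behave like the pair ending in compound 3 or the pair ending in compound 4. Also open, on these data alone, is how an acetyl group in place of tert-butoxycarbonyl on the same amine nitrogen would read on each core, which would help separate the removal of tert-butoxycarbonyl from the presence of a free amine.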